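Replacing Sulfamoyl with Methanesulfonamido on a Kinase Binder

A few compounds are considered here, and "the series" means these few. Any claim that something is new, unique, unknown or untested is made for them only; others in the source may bear on it.

Compound 1: `CCCS(=O)(=O)Nc1ccc(F)c(C(=O)c2n[nH]c3ncc(-c4ccc(F)cc4C)cc23)c1F`, 14%
Compound 2: `CCCS(=O)(=O)Nc1ccc(F)c(C(=O)c2n[nH]c3ncc(-c4ccc(S(N)(=O)=O)cc4)cc23)c1F`, 0.25%

In an assay for binding affinity to dual specificity mitogen-activated protein kinase kinase 4 (Homo sapiens), read by KINOMEscan, tested at 100 nM (on this read-out lower numbers stand for a stronger effect and higher numbers for a weaker effect at the one concentration tested), compound 1 gives 14%, while compound 2 gives 0.25%, the lowest of the two numbers and beyond the scatter from compound 1. Going by the values given here, the single measured step is a number 13.8 percentage points lower from compound 1 to compound 2 (beyond the scatter), which concerns the whole aryl group and not the change considered here.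

Compound 3 is `CCCS(=O)(=O)Nc1ccc(F)c(C(=O)c2n[nH]c3ncc(-c4ccc(NS(C)(=O)=O)cc4)cc23)c1F`. It differs from compound 2 by methanesulfonamido in place of sulfamoyl on an aromatic carbon. Among the compounds with values here, no measured step touches this exchange, so the expectation rests on compound 2 alone: its value of 0.25% is already a small number on this read-out, and the step expected from it is a number 0.8 percentage points higher from compound 2 to compound 3 (within the scatter), not beyond the scatter. Compound 3 is therefore estimated at 1%, within a range from 0.1% to 10%.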

Compound 3, a percentage reported as activity, at one concentration (the size of the read-out at that concentration, not a potency): 0.85%
The estimate for compound 3 lay 0.2 percentage points above the measured number; measured number inside the range.
By their numbers in this assay, from the lowest: compounds 2 and 3 (each within the scatter of the next); then compound 1.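

In this assay, methanesulfonamido in place of sulfamoyl, on an aromatic carbon para to a large group, gives a number 0.6 percentage points higher from compound 2 to compound 3 (within the scatter), so this exchange leaves the read-out within the scatter. The 4-(methanesulfonamido)phenyl group also holds the gain over 4-fluoro-2-methylphenyl, with a number 13.2 percentage points lower from compound 1 to compound 3 (beyond the scatter), which shows that the lower number seen earlier does not depend on the sulfamoyl group alone, since either of these two groups gives it. No evidence is available to explain this result.

The compounds shown leave open whether a carboxylic acid or an amine at this place would stay as low as compound 2 and compound 3, or whether a longer chain in place of the methyl of methanesulfonamido would do so. A read-out at one concentration also cannot say whether compound 2 and compound 3 share the same potency.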